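The source may report more compounds than this note shows. Statements on the series, on what has been measured and on what is new or still open speak of the compounds shown alone.

Compound 1 `COc1ccc(-c2cc(/C=C/C(=O)c3ccc(Cl)cc3)nc3cc(-c4ccccc4)nn23)cc1OC` gives 21300 nM in a functional assay on DU-145 cells (Homo sapiens) for antiproliferative activity, read by MTT assay, with a stated time of 24 h; a higher number here means a weaker inhibitor, a lower number a stronger inhibitor. Compound 2 `COc1cc(-c2cc(/C=C/C(=O)c3ccc(Cl)cc3)nc3cc(-c4ccccc4)nn23)cc(OC)c1OC` gives 29300 nM and compound 3 `COc1cc(-c2cc(/C=C/C(=O)c3ccccc3)nc3cc(-c4ccccc4)nn23)cc(OC)c1OC` gives 34300 nM, so the three numbers lie within the scatter of one another and compound 1 stands with them rather than apart. The step of a 1.4-fold higher number from compound 1 to compound 2 (0.14 log units; within the scatter) and the step of a 1.2-fold higher number from compound 2 to compound 3 (0.07 log units; within the scatter) both stayed inside the scatter. Compound 4 `COc1ccc(-c2cc(/C=C/C(=O)c3ccc(C)c(C)c3)nc3cc(-c4ccccc4)nn23)cc1OC` is not yet measured; it differs from compound 1 by 3,4-dimethylphenyl in place of 4-chlorophenyl on a carbonyl carbon. Going by the values given here, only a 1.2-fold higher number from compound 2 to compound 3 (0.07 log units; within the scatter) touches the same aryl on the carbonyl, and no measured step tests a 3,4-dimethylphenyl there. Compound 4 is therefore expected to show a 1.1-fold higher number from compound 1 to compound 4 (0.05 log units; within the scatter), nothing beyond the scatter. The estimate for compound 4 is 24000 nM, between 9000 nM and 65000 nM.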

Compound 4, half-maximal inhibitory concentration: 12100 nM
Compound 4: the middle estimate sits 2.0-fold (0.30 log units) above what was measured; measured number inside the range.
By their numbers in this assay, from the lowest: compounds 4, 1, 2 and 3 (each within the scatter of the next, the first and the last beyond it).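

On the aryl at the carbonyl carbon, 3,4-dimethylphenyl in place of 4-chlorophenyl gives a 1.8-fold lower number from compound 1 to compound 4 (0.25 log units; within the scatter) in this assay. This position thus accepts an aryl with two methyl groups and no chlorine, with a count of 8 heavy atoms in place of 7, and the number does not leave the scatter. No measurement bearing on this result is available to explain it. As far as these compounds go, it remains open whether an amine, a carboxylic acid or a longer chain on this aryl would move the number beyond the scatter.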